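This account rests on a few compounds, and the source may have more. Where it says the series, first, only, none or still open, it means among the compounds named here.

Three compounds share one core and have been run in an ADME assay on microsomes from liver (Homo sapiens) for metabolic stability, read by LC-MS, using NADPH, with stated times of 5 min and 30 min, tested at 1 uM; on this read-out higher numbers stand for fast clearance and lower numbers for slow clearance. Compound 1 `Cc1ncccc1-c1cnc(NCc2c(F)ccc3c2CCO3)c2ncc(=O)[nH]c12` gives 21 mL.min-1.g-1. Compound 3 `CN(C)Cc1ccc2c(c1)CN(c1cnc(NCc3c(F)ccc4c3CCO4)c3cn[nH]c(=O)c13)C2=O` gives 32 mL.min-1.g-1. Compound 2 `CC(=O)N1CCC(c2cnc(NCc3c(F)ccc4c3CCO4)c3cn[nH]c(=O)c23)CC1` gives 207 mL.min-1.g-1, the highest of the three numbers, and its gaps to compound 3, the nearest, and to compound 1, the furthest, both lie beyond the usual scatter of this measurement.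

Compound 4 `CN(c1ccn(C)n1)c1cnc(NCc2c(F)ccc3c2CCO3)c2cn[nH]c(=O)c12` has not yet been measured in this assay. It differs from compound 2 in one place: methyl(1-methyl-1H-pyrazol-3-yl)amino in place of 1-acetylpiperidin-4-yl on an aromatic carbon. The 1-acetylpiperidin-4-yl group, with its six-membered non-aromatic ring, leaves, and a methyl(1-methyl-1H-pyrazol-3-yl)amino group, carrying a five-membered aromatic ring with two hetero atoms, enters on an aromatic carbon of the core, ortho to a fused ring and two atoms from the ring nitrogen.

For the measured compounds named here, no pair of measured compounds differs in exactly this way, so the size of the step is a judgement. Within this set, the two compounds bearing aromatic groups at the varied position, compound 1 with 21 mL.min-1.g-1 and compound 3 with 32 mL.min-1.g-1, both sit well below compound 2, whose value is 207 mL.min-1.g-1. On that basis a step downward in this assay, beyond the scatter, is expected for compound 4, of the size a 3.5-fold lower number from compound 2 to compound 4 (0.54 log units; beyond the scatter). Compound 4 is therefore estimated at 60 mL.min-1.g-1, within a range of 20 mL.min-1.g-1 to 160 mL.min-1.g-1.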

Compound 4, intrinsic clearance in microsomes: 62 mL.min-1.g-1
Compound 4: the middle estimate sits 1.0-fold (0.01 log units) below what was measured, within the range that was stated.
By their numbers in this assay, from the lowest: compounds 1, 3 and 4 (each within the scatter of the next, the first and the last beyond it); then compound 2.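

For the compounds shown here, the earlier compounds held no pair differing in one place, so this is the first change at this position that can be read on its own. In this assay, putting methyl(1-methyl-1H-pyrazol-3-yl)amino in place of 1-acetylpiperidin-4-yl gives a 3.3-fold lower number from compound 2 to compound 4 (0.52 log units; beyond the scatter) and shows that the group on this aromatic carbon can by itself move clearance by more than the scatter, even though the step is only modest. Nothing shown explains why the number falls.

The exchange alters several features at once: the non-aromatic ring and its acetyl group leave, while an amino nitrogen, its methyl and a five-membered aromatic ring enter, so the compounds shown do not reveal which of these changes matters. A plain piperidin-4-yl without the acetyl group, a morpholin-4-yl or a 1-methyl-1H-pyrazol-3-yl joined directly to the core would each differ from compound 2 or compound 4 in a smaller way and could help to separate these contributions.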